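A few compounds are considered here, and "the series" means these few. Any claim that something is new, unique, unknown or untested is made for them only; others in the source may bear on it.

Measured compounds:
Compound 1 `CCCN(Cc1ccc(OC(F)(F)F)cc1)[C@@H]1COc2nc([N+](=O)[O-])cn2C1`: in a physicochemical assay for solubility, at pH 6.8 (a higher number here means a more soluble compound, a lower number a less soluble compound), compound 1 gives < 2 ug/mL, which is a limit of the assay rather than a number.
Compound 2 `O=[N+]([O-])c1cn2c(n1)OC[C@@H](NCc1ccc(OC(F)(F)F)c(Oc3ccccc3)c1)C2`: compound 2 gives < 2 ug/mL, again a limit of the assay.
Compound 3 `O=[N+]([O-])c1cn2c(n1)OC[C@@H](NCc1ccc(OC(F)(F)F)cc1F)C2`: compound 3 gives 72 ug/mL.

Compound 2 therefore stands at the floor of the solubility values shown; its reading is a limit, and (the limit of < 2 ug/mL in this assay, at which 2 of the 3 values shown sit). Among the measured compounds shown here, no pair among the three measured compounds differs in only one place, so no measured step is available to lean on.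

Compound 4 `O=[N+]([O-])c1cn2c(n1)OC[C@@H](NCc1ccc(OC(F)(F)F)c(Cl)c1)C2` differs from compound 2 by chloro in place of phenoxy on an aromatic carbon. For the measured compounds named here, with no measured step to guide the size, the expectation rests on compound 3, which has no phenoxy and gives 72 ug/mL. Compound 4 is expected to move up out of the limit, with a step of an at least 12-fold higher number from compound 2 to compound 4 (1.09 log units; beyond the scatter) that is estimated to lie well beyond the usual scatter. The estimated solubility of compound 4 is 25 ug/mL, with a range from 5 ug/mL to 100 ug/mL.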

Compound 4, solubility: 77 ug/mL
Compound 4: middle estimate off by 3.1-fold (0.49 log units), on the low side, and the stated range covers the measured number.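

In this assay, among the compounds shown here, this pair gives the first comparison of compounds that differ in one place. It shows that the aromatic carbon ortho to a trifluoromethoxy group is a position where the substituent matters: chloro in place of phenoxy gives an at least 38-fold higher number from compound 2 to compound 4 (1.58 log units; beyond the scatter). The change takes away a six-membered aromatic ring of carbon only and a hydrogen-bond acceptor, but this single pair cannot separate the loss of phenoxy from the arrival of chloro. The size of the step is only a lower bound, because the reading of compound 2 is a limit: the limit of < 2 ug/mL in this assay, at which 2 of the 4 values shown sit.

Going by these compounds, how much of the step belongs to the departing phenoxy and how much to the chloro remains open. A methoxy group or a nitrile on this carbon would help to separate the two, and whether the step holds with a propyl group on the amine nitrogen is also unresolved.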